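Swapping a Chlorophenyl for a Hydroxyethyl Chain

A few compounds are considered here, and "the series" means these few. Any claim that something is new, unique, unknown or untested is made for them only; others in the source may bear on it.

Compound 1 `O=C(Nc1ccc(NCc2ccc(Cl)cc2)cc1Cl)c1cc(Cl)ccc1O`: 59700 nM
Compound 2 `O=C(Nc1ccc(NCc2cc(Cl)cc(C(F)(F)F)c2)cc1Cl)c1cc(Cl)ccc1O`: 30900 nM

In an ADME assay on A549 cells (Homo sapiens) for cytotoxicity, read by resazurin assay, with a stated time of 48 h (on this read-out higher numbers stand for lower toxicity in this test and lower numbers for higher toxicity in this test), compound 1 gives 59700 nM, the highest of the two numbers, while compound 2 gives 30900 nM, a gap that lies within the scatter, so the two stand level. Compound 3 `O=C(Nc1ccc(NCCCO)cc1Cl)c1cc(Cl)ccc1O` differs from compound 1 in one place: 2-hydroxyethyl in place of 4-chlorophenyl on a saturated chain carbon bound to a nitrogen on an aromatic ring. For the measured compounds named here, no step between measured compounds is known, so the expectation rests on this change alone. The step expected in this assay is estimated as a 1.5-fold higher number from compound 1 to compound 3 (0.18 log units; within the scatter), toward a higher number. Compound 3 is therefore expected to give 90000 nM, within a range of 40000 nM to 200000 nM.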

Compound 3, half-maximal cytotoxic concentration: 106000 nM
Estimate against measurement, compound 3: 1.2-fold (0.07 log units) below; the range from low to high includes it.
By their numbers in this assay, from the lowest: compounds 2, 1 and 3 (each within the scatter of the next, the first and the last beyond it).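

In this assay, 2-hydroxyethyl in place of 4-chlorophenyl on this saturated chain carbon gives a 1.8-fold higher number from compound 1 to compound 3 (0.25 log units; within the scatter), so compound 3 and compound 1 stand level. At this position, then, the aromatic ring and its chlorine can give way to an open chain ending in a hydroxyl group without moving the reading beyond the scatter. The compounds shown leave open whether an amine or a carboxylic acid at the end of the chain, or a longer chain, would read the same. No measurement at hand explains why these two compounds read alike.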